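A few compounds are considered here, and "the series" means these few. Any claim that something is new, unique, unknown or untested is made for them only; others in the source may bear on it.

Of the compounds shown here, three sharing one core have so far been read in a functional assay on HeLa cells (Homo sapiens) for antiproliferative activity, read by MTT assay, with a stated time of 48 h; on this read-out higher numbers stand for weaker inhibition of growth and lower numbers for stronger inhibition of growth. Compound 2 `COC(=O)N1N=C(c2ccccc2)CC1c1ccc(OC)cc1` gives 12700 nM, compound 3 `COC(=O)N1N=C(c2ccccc2)CC1c1ccc(OC)c(OC)c1` gives 5480 nM, and compound 1 `COC(=O)N1N=C(c2ccccc2)CC1c1cc(OC)c(OC)c(OC)c1` gives 2180 nM. Compound 3 therefore holds the middle of the three numbers, beyond the scatter from each of the other two.

Compound 4 `COC(=O)N1N=C(c2ccccc2)CC1c1cc(OC)c(OC)cc1OC` arises from compound 3 through a single change: methoxy in place of hydrogen on an aromatic carbon. This is methoxy in place of hydrogen on an aromatic carbon, ortho to a large group, meta to a methoxy group and para to a methoxy group.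

Two measured steps of the same kind bear on this change. One is a 2.3-fold lower number from compound 2 to compound 3 (0.37 log units; beyond the scatter), on gaining a methoxy. The other is a 2.5-fold higher number from compound 1 to compound 3 (0.40 log units; beyond the scatter), on losing a methoxy. Both are modest, and among these three compounds none goes against the link between more methoxy and a lower number. However, no measured compound has a methoxy ortho to a large group, so the transfer is uncertain.

A modest move toward a lower number is expected in this assay, smaller than the two measured steps. The expected step is a 1.5-fold lower number from compound 3 to compound 4 (0.18 log units; within the scatter). The estimate for compound 4 is 3600 nM, with an expected range of 1400 nM to 9000 nM.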

Compound 4, concentration for 50% growth inhibition: 2470 nM
The estimate for compound 4 lay 1.5-fold (0.16 log units) above the measured number; measured number inside the range.
By their numbers in this assay, from the lowest: compounds 1 and 4 (each within the scatter of the next); then compound 3; then compound 2.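

In this assay, a methoxy ortho to a large group, a place not occupied in any earlier compound, gives a 2.2-fold lower number from compound 3 to compound 4 (0.35 log units; beyond the scatter) and so shifts the number beyond the scatter. Among these compounds, this step is printed as modest, as is a 2.3-fold lower number from compound 2 to compound 3 (0.37 log units; beyond the scatter), so the new position supports a change of the same class as the earlier gain of a methoxy, and the link between more methoxy and a lower number now has no compound against it among all four compounds. No measurement bears on the reason for this step, and the series gives no account of what the added methoxy does.

The compounds shown leave open whether the step depends on the methoxy itself, as only this group appears at this place; a hydroxy, a fluorine, an ethoxy or an amine there would separate a general effect of substitution from one tied to methoxy. Going by these compounds, it also remains open whether a methoxy at this place gives a step of similar size without the methoxy groups that stand meta and para to it in compound 4.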